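A few compounds are considered here, and "the series" means these few. Any claim that something is new, unique, unknown or untested is made for them only; others in the source may bear on it.

In a functional assay on A549 cells (Homo sapiens) for inhibition, read by MTT assay, with a stated time of 48 h (a lower number here means a stronger inhibitor, a higher number a weaker inhibitor), compound 1 `CCCCC(=O)Nc1ccc(N2CCN(c3ccc(OC[C@@H]4CO[C@@](Cn5cncn5)(c5ccc(Cl)cc5Cl)O4)cc3)CC2)cc1` gives 5340 nM.
In this assay compound 2 `CCCC(=O)Nc1ccc(N2CCN(c3ccc(OC[C@@H]4CO[C@@](Cn5cncn5)(c5ccc(Cl)cc5Cl)O4)cc3)CC2)cc1` gives 2990 nM.
In this assay compound 3 `Cc1ccc(C(=O)Nc2ccc(N3CCN(c4ccc(OC[C@@H]5CO[C@@](Cn6cncn6)(c6ccc(Cl)cc6Cl)O5)cc4)CC3)cc2)o1` gives 4750 nM.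

Among these three numbers compound 3 holds the second highest, yet all three sit close together: the step of a 1.1-fold lower number from compound 1 to compound 3 (0.05 log units; within the scatter) and the step of a 1.6-fold higher number from compound 2 to compound 3 (0.20 log units; within the scatter) are both within the usual scatter, as is a 1.8-fold lower number from compound 1 to compound 2 (0.25 log units; within the scatter). Compound 4 `O=C(Nc1ccc(N2CCN(c3ccc(OC[C@@H]4CO[C@@](Cn5cncn5)(c5ccc(Cl)cc5Cl)O4)cc3)CC2)cc1)c1cccs1` shares the whole core of compound 3 and differs in one place: thiophen-2-yl in place of 5-methylfuran-2-yl on a carbonyl carbon. Among the measured compounds shown here, the steps that bear on this change are those that already swapped the group on the carbonyl carbon, from butyl or propyl to 5-methylfuran-2-yl, and neither moved the number beyond the scatter. On that basis, exchanging one five-membered aromatic ring with one hetero atom for another is expected to give a step of about a 1.1-fold lower number from compound 3 to compound 4 (0.02 log units; within the scatter), that is, no shift beyond the scatter in either direction. The estimate for compound 4 in this assay is therefore 4500 nM, with a range from 1500 nM to 13000 nM.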

Compound 4, half-maximal inhibitory concentration: 4330 nM
The estimate for compound 4 lay 1.0-fold (0.02 log units) above the measured number; the range from low to high includes it.
By their numbers in this assay, from the lowest: compounds 2, 4, 3 and 1 (each within the scatter of the next).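

With compound 4, a second five-membered aromatic ring stands on the carbonyl carbon, so one ring can be compared directly with another: in this assay the step of a 1.1-fold lower number from compound 3 to compound 4 (0.04 log units; within the scatter) lies within the scatter. Thiophen-2-yl also matches the open chains at this position, since the step of a 1.4-fold higher number from compound 2 to compound 4 (0.16 log units; within the scatter) from propyl and the step of a 1.2-fold lower number from compound 1 to compound 4 (0.09 log units; within the scatter) from butyl are within the scatter as well. Across these four compounds, then, neither ring for ring nor ring for chain moves the number beyond the scatter, and no measurement given here offers a reason for this.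

Going by these compounds, it remains open whether a different kind of group on this carbonyl carbon, such as a phenyl ring, an amine-bearing chain or a much longer chain, would move the number beyond the scatter. On these data alone, the effect of replacing the amide hydrogen, or of any change to the shared core, also remains open.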